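Adding a Methoxy Group to Compound 1: What to Expect

The source may report more compounds than this note shows. Statements on the series, on what has been measured and on what is new or still open speak of the compounds shown alone.

Compound 1 `COc1ccc(/C=C/C(=O)c2ccc(N)c(-c3ccc(F)cc3)c2)cc1OC`: 6640 nM
Compound 2 `COc1ccc(/C=C/C(=O)c2cccc(-c3ccc(F)cc3)c2)cc1OC`: 6490 nM
Compound 3 `COc1ccc(/C=C/C(=O)c2ccc(NC(C)=O)c(-c3ccc(F)cc3)c2)cc1OC`: 5350 nM

In a functional assay on SW480 cells (Homo sapiens) for cytotoxicity, read by sulforhodamine B assay, with a stated time of 48 h (on this read-out higher numbers stand for weaker inhibition and lower numbers for stronger inhibition), compound 1 stands within the scatter of both other compounds: a 1.0-fold lower number from compound 1 to compound 2 (0.01 log units; within the scatter) and a 1.2-fold lower number from compound 1 to compound 3 (0.09 log units; within the scatter). Compound 2 and compound 3 are likewise close, a 1.2-fold lower number from compound 2 to compound 3 (0.08 log units; within the scatter). Compound 4 `COc1cc(/C=C/C(=O)c2ccc(N)c(-c3ccc(F)cc3)c2)cc(OC)c1OC` differs from compound 1 by methoxy in place of hydrogen on an aromatic carbon. The three measured steps all concern an amino or acetamido group, not a methoxy group, so none of them bears directly on this change. Every measured step here stays within the scatter, and nothing in these data points to a step beyond it in this assay in either direction. Compound 4 is therefore expected to give about 6600 nM, within a range of 2500 nM to 17000 nM. This estimate means an expected 1.0-fold lower number from compound 1 to compound 4 (0.00 log units; within the scatter).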

Compound 4, half-maximal inhibitory concentration: 6120 nM
For compound 4 the middle estimate is 1.1-fold (0.03 log units) above the measured one; measured number inside the range.
By their numbers in this assay, from the lowest: compounds 3, 4, 2 and 1 (each within the scatter of the next).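

In this assay there is a 1.1-fold lower number from compound 1 to compound 4 (0.04 log units; within the scatter) when methoxy replaces hydrogen on the aromatic carbon ortho to a methoxy group. This is the first step shown on the ring carrying the methoxy groups, and it stays within the scatter, as the steps at the amino group did. No measurement shown gives a reason for this result.

Still open, on these data alone, is whether a different group on this same carbon, such as an amine, a carboxylic acid or a longer chain like butoxy, would also stay within the scatter of compound 1.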